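The compounds below may be only part of what the source reports. "The series", "measured", "known", "first", "only" and "open" are said of these compounds alone.

Measured compounds:
- Compound 1 `CCNc1nc(=O)c2cc(C(F)(F)F)cc([N+](=O)[O-])c2s1` — in an ADME assay on Vero cells (Chlorocebus sabaeus) for cytotoxicity, read by MTT assay, with a stated time of 72 h (a lower number here means a stronger inhibitor, a higher number a weaker inhibitor), compound 1 gives > 100000 nM, a limit of the assay.
- Compound 2 `CC(C)CNc1nc(=O)c2cc(C(F)(F)F)cc([N+](=O)[O-])c2s1` — in this assay compound 2 gives > 100000 nM, a limit of the assay.
- Compound 3 `O=c1nc(N2CCCC2)sc2c([N+](=O)[O-])cc(C(F)(F)F)cc12` — in this assay compound 3 gives > 100000 nM, a limit of the assay.

All three values sit at the limit of > 100000 nM in this assay, at which 3 of the 3 values shown sit, so compound 3 cannot be placed above or below its two neighbours; only a limit is known for it. The steps among the measured compounds are accordingly unreadable: a step that the two limits leave unreadable from compound 1 to compound 2, a step that the two limits leave unreadable from compound 1 to compound 3 and a step that the two limits leave unreadable from compound 2 to compound 3 each run between two limits, and none tells the size or direction of an effect in this assay.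

Compound 4 `O=C(O)C1CCN(c2nc(=O)c3cc(C(F)(F)F)cc([N+](=O)[O-])c3s2)CC1` arises from compound 3 by the change (4-carboxypiperidin-1-yl in place of pyrrolidin-1-yl on an aromatic carbon). Of the measured steps, those arriving at compound 3 bear most on this change, but both are unreadable, so no step beyond the scatter can be derived in either direction. Compound 4 is therefore expected to sit again at the limit, with an estimated value of 100000 nM and a range from 50000 nM to 300000 nM. The expected step is a number no higher from compound 3 to compound 4 (the limit leaves the size open), which is estimated to be within the scatter.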

Compound 4, half-maximal inhibitory concentration: > 100000 nM
Compound 4: only a limit was reported; the forecaster's own chance of this, stated with the estimate: 85%; the middle value sits exactly at the limit.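

Compound 4 joins compound 1, compound 2 and compound 3 at a limit in this assay, so none of the steps to compound 4 can be read: the limit of > 100000 nM in this assay, at which 4 of the 4 values shown sit.

The compounds shown leave open whether any of these four truly differ from one another in this assay.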